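Oxetan-2-yl in place of oxolan-3-yl: an unmeasured step

The source may hold more compounds than are shown below. What is called first, only, known or untested is meant among the compounds shown, and "the series" means these compounds.

In a physicochemical assay for lipophilicity, read by HPLC, measured as octanol-water partition, at pH 7.4 (a lower number here means a more polar compound, a higher number a more lipophilic compound), two compounds sharing the same core have been measured so far. Compound 2 `NC(=O)[C@@H](CCC(F)(F)F)N(C[C@H]1CCOC1)S(=O)(=O)c1ccc(Cl)cc1` gives 2.8 and compound 1 `NC(=O)[C@@H](CCC(F)(F)F)N(CC1COC1)S(=O)(=O)c1ccc(Cl)cc1` gives 2.5, so these two values lie within the scatter of each other. Compound 3 `NC(=O)[C@@H](CCC(F)(F)F)N(C[C@H]1CCO1)S(=O)(=O)c1ccc(Cl)cc1` keeps the shared core and changes one group: oxetan-2-yl in place of oxolan-3-yl on a saturated chain carbon bound to a sulfonamide nitrogen. In words, oxetan-2-yl stands in place of oxolan-3-yl on a saturated chain carbon bound to a sulfonamide nitrogen.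

For the measured compounds named here, only one measured step bears on this change. It exchanges oxetan-3-yl for oxolan-3-yl at the same place, and it reads a number 0.30 log units higher from compound 1 to compound 2 (within the scatter). That step runs in the opposite direction from oxetan to oxolan, and its size stays within the scatter. Going by the values given here, no compound carrying oxetan-2-yl has been measured, so the comparison with oxetan-3-yl remains open. In this assay, the expected change is a number 0.20 log units lower from compound 2 to compound 3 (within the scatter), and no step beyond the scatter is expected. For compound 3 the estimated value is 2.6, with an expected range from 2.2 to 3.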

Compound 3, distribution coefficient: 2.6
Estimate against measurement, compound 3: no gap at the digits printed; low and high end bracket the measured number.
By their numbers in this assay, from the lowest: compounds 1, 3 and 2 (each within the scatter of the next).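

In this assay, oxetan-2-yl in place of oxolan-3-yl on a saturated chain carbon bound to a sulfonamide nitrogen gives a number 0.20 log units lower from compound 2 to compound 3 (within the scatter). The new compound also allows a comparison the first two could not offer, between two attachment points of the four-membered ring: oxetan-2-yl in place of oxetan-3-yl gives a number 0.10 log units higher from compound 1 to compound 3 (within the scatter). With both steps inside the scatter, this assay does not separate these three ring groups at this place, whether the ring is four-membered or five-membered and wherever the four-membered ring is attached, and no supporting data offer an explanation for these readings.

The compounds shown span only neutral rings with a single oxygen, so they do not tell whether a group of another kind at this place, such as an amine or a carboxylic acid, would give a step beyond the scatter. They also leave open how the opposite stereocentre in oxetan-2-yl would read, since compound 3 carries only one defined arrangement.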